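A Bulkier Amine Side Group After Three Limit Values

The source may report more compounds than this note shows. Statements on the series, on what has been measured and on what is new or still open speak of the compounds shown alone.

Three compounds share a core and differ in the group on a saturated chain carbon bound to an aromatic carbon: compound 1 (`COc1ccc(/C=C\c2cc(OC)c(OC)c(OC)c2)cc1OCc1ccc(CN2C[C@H](O)C[C@@H]2C(=O)O)cc1`), compound 2 (`COc1ccc(/C=C\c2cc(OC)c(OC)c(OC)c2)cc1OCc1ccc(CN[C@H](C(=O)O)[C@H](C)O)cc1`) and compound 3 (`COc1ccc(/C=C\c2cc(OC)c(OC)c(OC)c2)cc1OCc1ccc(CN2CC[C@@H](O)C2)cc1`). In an ADME assay on HEK293 cells (Homo sapiens) for cytotoxicity, read by CCK-8 assay, with a stated time of 48 h (on this read-out lower numbers stand for stronger inhibition and higher numbers for weaker inhibition), compound 1 gives > 50000 nM as a limit of the assay, not a number. Compound 2 gives > 50000 nM as a limit too. Compound 3, the starting point here, also gives > 50000 nM as a limit. What the set offers so far is the limit of > 50000 nM in this assay, at which 3 of the 3 values shown sit, and nothing finer.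

Compound 4 (`COc1ccc(/C=C\c2cc(OC)c(OC)c(OC)c2)cc1OCc1ccc(CN2CCCCC2C(=O)NCCN)cc1`) carries 2-((2-aminoethyl)carbamoyl)piperidin-1-yl in place of the 3-hydroxypyrrolidin-1-yl of compound 3, a change counted as 2-((2-aminoethyl)carbamoyl)piperidin-1-yl in place of 3-hydroxypyrrolidin-1-yl on a saturated chain carbon bound to an aromatic carbon on that same carbon.

The measured changes at this place are a step that the two limits leave unreadable from compound 1 to compound 3 and a step that the two limits leave unreadable from compound 2 to compound 3 along with a step that the two limits leave unreadable from compound 1 to compound 2 as well. None of them gives a size, so the direction of any move is only a cautious guess, leaning slightly toward stronger inhibition. The expected outcome is an at least 1.2-fold lower number from compound 3 to compound 4 (0.09 log units; that floor lies within the scatter) and a reading at the same limit remains quite possible. In this assay the estimate for compound 4 is 40000 nM with an expected range of 12000 nM to 80000 nM overall.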

Compound 4, half-maximal inhibitory concentration: > 50000 nM
Compound 4 gave a limit, no number (the forecaster's own chance of this, stated with the estimate: 55%); middle value at least 1.2-fold (0.09 log units) from the limit.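

In this assay compound 4 gives > 50000 nM, which is a limit of the assay and not a number. The steps to compound 4 from compound 1, compound 2 and compound 3 cannot be read. The compounds shown leave open whether any of these side groups changes the read-out, as they offer only one reading: the limit of > 50000 nM in this assay, at which 4 of the 4 values shown sit.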